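The source may report more compounds than this note shows. Statements on the series, on what has been measured and on what is new or still open speak of the compounds shown alone.

Measured so far:
compound 1 `COc1ccc(-c2cnc(NC(=O)c3ccccc3C)n2C)cc1`: > 100000 nM
compound 2 `Cn1c(-c2ccccc2)cnc1NC(=O)c1ccccc1Cl`: > 50000 nM

In a toxicity assay on THP-1 cells (Homo sapiens) for inhibition (on this read-out lower numbers stand for higher toxicity in this test and higher numbers for lower toxicity in this test), compound 2 gives only a limit, > 50000 nM, (the limit of > 50000 nM in this assay, at which 1 of the 2 values shown sits). Compound 1 likewise gives only a limit in this assay, > 100000 nM, (the limit of > 100000 nM in this assay, at which 1 of the 2 values shown sits). Neither value is a number, so compound 2 stands at the low-toxicity end of what this assay can show. Compound 3 `COc1ccc(-c2cnc(NC(=O)c3ccccc3Cl)n2C)cc1` differs from compound 2 by a single change: methoxy in place of hydrogen on an aromatic carbon. Within the data shown here, no step between measured compounds is known, so this change has no precedent here. With both measured values sitting at limits, the step that the limit leaves unreadable from compound 2 to compound 3 is expected to stay within the scatter. Compound 3 is expected at about 100000 nM, within 50000 nM to 300000 nM, most likely again reported as a limit.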

Compound 3, half-maximal cytotoxic concentration: > 50000 nM
Compound 3 was reported as a limit; the forecaster's own chance of this, stated with the estimate: 85%; the middle value is on the limit's open side.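

Among these compounds, compound 1, compound 2 and compound 3 all stand as limits in this assay, and no step among them can be read. The compounds shown leave open whether methoxy in place of hydrogen, or chloro in place of methyl, changes this read-out at all.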